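This account rests on a few compounds, and the source may have more. Where it says the series, first, only, none or still open, it means among the compounds named here.

Compound 1, `CCCCCNc1nc(NCc2ccco2)c2cc(F)ccc2n1`, was entered in a functional assay on HT-29 cells (Homo sapiens) for cytotoxicity, read by MTT assay, with a stated time of 2 days, tested at 10 uM (a higher number here means more inhibition at the concentration tested (going by the name of the read-out), a lower number less inhibition), and for compound 1 this assay gives "not determined" (no result reported). Compound 2, `CN(C)CCCNc1nc(NCc2ccco2)c2ccccc2n1`, stands the same way: in this assay compound 2 gives "not determined" (no result reported). Only compound 3, `Clc1cccc(N2CCN(CCCNc3nc(NCc4ccco4)c4ccccc4n3)CC2)c1Cl`, supplies a figure, and in this assay compound 3 gives 94.1%. Compound 1 therefore stands without a value of its own, sharing that blank with compound 2, while compound 3 alone shows how strong an effect this series can reach.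

Compound 4, `CCN(CC)CCNc1nc(NCc2ccco2)c2cc(F)ccc2n1`, differs from compound 1 in one place: diethylamino in place of propyl on a saturated chain carbon, two bonds along the chain from a nitrogen on an aromatic ring. Compound 1 has no number. No size or direction can therefore be assigned to the step from compound 1 to compound 4 in this assay. For the measured compounds named here, the only anchor is compound 3, whose chain also bears an amine and whose reading of 94.1% sits high. On that basis compound 4 is expected to give about 75%, with a likely range from 35% to 98%.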

Compound 4, a percentage reported as inhibition, at one concentration (the size of the read-out at that concentration, not a potency): 27.5%
The estimate for compound 4 lay 47.5 percentage points above the measured number; measured number below the stated range.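

No step can be read from compound 1 to compound 4, since compound 1 has no number in this assay, and no measured finding here offers an explanation. The compounds shown leave open what diethylamino in place of propyl does to inhibition on this core.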